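The source may report more compounds than this note shows. Statements on the series, on what has been measured and on what is new or still open speak of the compounds shown alone.

In a functional assay on HCT-116 cells (Homo sapiens) for cytotoxicity, read by sulforhodamine B assay (a higher number here means a weaker inhibitor of growth, a lower number a stronger inhibitor of growth), compound 1 `Nc1ncnc2c1nc(NCc1ccc(Cl)c(Cl)c1)n2[C@@H]1O[C@H](COCc2ccccc2)[C@@H](O)[C@H]1O` reaches only a limit, > 80000 nM. Compound 2 `Nc1ncnc2c1nc(NCc1ccc(Cl)c(Cl)c1)n2[C@@H]1O[C@H](COCc2cc(F)c(F)c(F)c2)[C@@H](O)[C@H]1O` gives 13000 nM. Compound 3 `Nc1ncnc2c1nc(NCc1ccc3ncccc3c1)n2[C@@H]1O[C@H](COCc2ccc(C(F)(F)F)cc2)[C@@H](O)[C@H]1O` gives 27000 nM, the higher of the two actual numbers, and its gap to compound 2 lies beyond the scatter.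

Compound 4 `Nc1ncnc2c1nc(NCc1ccc3ncccc3c1)n2[C@@H]1O[C@H](COCc2cc(F)c(F)c(F)c2)[C@@H](O)[C@H]1O` keeps everything in compound 3 except one group, with 3,4,5-trifluorophenyl in place of 4-(trifluoromethyl)phenyl on a saturated chain carbon bound to an oxygen on a saturated carbon. The difference counts as follows: 3,4,5-trifluorophenyl in place of 4-(trifluoromethyl)phenyl on a saturated chain carbon bound to an oxygen on a saturated carbon.

For the measured compounds named here, one measured step bears on this change: an at least 6.1-fold lower number from compound 1 to compound 2 (0.78 log units; beyond the scatter), where the same 3,4,5-trifluorophenyl entered in place of phenyl. That step is only a partial guide. It starts from a limit, the group leaving it is a different one, and compound 1 also differs from compound 3 elsewhere in its structure. Going by the values given here, no measured step starts from 4-(trifluoromethyl)phenyl.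

A small move in this assay towards a lower number is therefore expected, not clearly beyond the scatter. The expected change is a 1.6-fold lower number from compound 3 to compound 4 (0.20 log units; within the scatter). The estimate for compound 4 is 17000 nM, with an expected range from 7000 nM to 40000 nM.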

Compound 4, concentration for 50% growth inhibition: 18000 nM
Beside the measured number, compound 4's estimate is 1.1-fold (0.02 log units) below it, and the stated range covers the measured number.
By their numbers in this assay, from the lowest: compounds 2, 4 and 3 (each within the scatter of the next, the first and the last beyond it). At a limit, above all of these: compound 1.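

In this assay, for the compounds shown here, a 1.5-fold lower number from compound 3 to compound 4 (0.18 log units; within the scatter), and this is the first exchange at the position on a saturated chain carbon bound to an oxygen on a saturated carbon that starts from a substituted phenyl, so 4-(trifluoromethyl)phenyl and 3,4,5-trifluorophenyl cannot be told apart when quinolin-6-yl is kept on the other side. Going by these compounds alone, the other place is now also seen on its own for the first time: with 3,4,5-trifluorophenyl held fixed, a 1.4-fold higher number from compound 2 to compound 4 (0.14 log units; within the scatter), which also leaves quinolin-6-yl and 3,4-dichlorophenyl on a saturated chain carbon bound to a nitrogen on an aromatic ring without a readable difference. Compound 1, with plain phenyl, is the only compound shown that stands apart, and the size of its gap cannot be stated because its value is a limit: the limit of > 80000 nM in this assay, at which 1 of the 4 values shown sits.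

On these data alone, it stays open whether plain phenyl would also stand apart with quinolin-6-yl on the other side, and whether 4-(trifluoromethyl)phenyl would match 3,4,5-trifluorophenyl with 3,4-dichlorophenyl there. Also open, as far as these compounds go, is what a pyridine ring, or a phenyl carrying an amine or a carboxylic acid, would do in place of 3,4,5-trifluorophenyl.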